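The source may hold more compounds than are shown below. What is called first, only, known or untested is meant among the compounds shown, and "the series" means these compounds.

Measured so far in a functional assay on HeLa cells (Homo sapiens) for inhibition, read by MTT assay, with a stated time of 72 h; a lower number here means a stronger inhibitor, a higher number a weaker inhibitor:

compound 1, `COc1cc(OC)c(OC)cc1/C=C/C(=O)c1ccc(C)cc1` — 42200 nM
compound 2, `COc1cc(OC)c(OC)cc1/C=C/C(=O)c1ccc(-c2c[nH]cn2)cc1` — a limit of the assay, > 150000 nM
compound 3, `COc1ccc(C(=O)/C=C/c2cc(OC)c(OC)cc2OC)cc1` — 37600 nM

Compound 3 and compound 1 sit within the scatter of each other, a 1.1-fold lower number from compound 1 to compound 3 (0.05 log units; within the scatter), so the two cannot be told apart on these numbers. The result for compound 2 is a limit only, (the limit of > 150000 nM in this assay, at which 1 of the 3 values shown sits). Relative to that limit the two other compounds stand clearly apart: an at least 3.5-fold higher number from compound 1 to compound 2 (0.55 log units; beyond the scatter), and an at least 3.9-fold lower number from compound 2 to compound 3 (0.60 log units; beyond the scatter).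

Compound 4, `COc1cc(OC)c(OC)cc1/C=C/C(=O)c1ccc(Br)cc1`, differs from compound 3 by bromo in place of methoxy on an aromatic carbon. Among the measured compounds shown here, the only measured step at that same aromatic carbon is the exchange of methyl for methoxy, a 1.1-fold lower number from compound 1 to compound 3 (0.05 log units; within the scatter), which stayed within the scatter; the one step that moved the number beyond the scatter there brought in the 1H-imidazol-4-yl ring, an at least 3.5-fold higher number from compound 1 to compound 2 (0.55 log units; beyond the scatter). Bromo, like methyl and methoxy, carries no ring, so among the steps seen nothing points to a shift beyond the scatter in this assay for bromo in place of methoxy on an aromatic carbon.

The expected step is accordingly a 1.0-fold higher number from compound 3 to compound 4 (0.00 log units; within the scatter), no change beyond the scatter. Compound 4 is estimated at 38000 nM in this assay, with a range from 15000 nM to 95000 nM.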

Compound 4, half-maximal inhibitory concentration: 31700 nM
The estimate for compound 4 lay 1.2-fold (0.08 log units) above the measured number; low and high end bracket the measured number.
By their numbers in this assay, from the lowest: compounds 4, 3 and 1 (each within the scatter of the next). At a limit, above all of these: compound 2.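

In this assay, bromo in place of methoxy stays within the scatter, a 1.2-fold lower number from compound 3 to compound 4 (0.07 log units; within the scatter), and bromo in place of methyl does the same, a 1.3-fold lower number from compound 1 to compound 4 (0.12 log units; within the scatter). Methyl, methoxy and bromo therefore cannot be told apart at this aromatic carbon, even though the change from 4-methoxyphenyl to 4-bromophenyl removes the one hydrogen-bond acceptor that methoxy carries and leaves the number where it was. Bromo in place of 1H-imidazol-4-yl gives a step beyond the scatter, an at least 4.7-fold lower number from compound 2 to compound 4 (0.67 log units; beyond the scatter), so among the four compounds only the one carrying that ring stands apart, and the three groups without a ring form a single level.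

How far compound 2 lies from the other three stays open, since its result is only a limit: the limit of > 150000 nM in this assay, at which 1 of the 4 values shown sits.
Also open, on these data alone, is whether the separation follows the ring as such or the 1H-imidazol-4-yl group in particular, and whether a phenyl ring, an amine or a carboxylic acid on this aromatic carbon would leave the number at the level of compound 3 or move it beyond the scatter.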